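The source may report more compounds than this note shows. Statements on the series, on what has been measured and on what is new or still open speak of the compounds shown alone.

Working notes on the series, all read in a functional assay on cells (Cancer cell lines, Homo sapiens) for inhibition, with a stated time of 48 h; on this read-out lower numbers stand for stronger inhibition of growth and higher numbers for weaker inhibition of growth. Compound 1 (`COc1cc2c(/C=C3/C(=O)Nc4cc(Cl)ccc43)c(Cl)n(C)c2cc1C`) gives 15900 nM, compound 2 (`COc1cc2c(cc1C)N(C)C(=O)/C2=C/c1c(Cl)n(C)c2cc(C)c(OC)cc12`) gives 41700 nM and compound 3 (`COc1cc2c(/C=C3/C(=O)N(C)c4ccccc43)c[nH]c2cc1C`) gives 60300 nM. Compound 3 stands within the scatter of compound 2, while compound 1 has the lower number, beyond the scatter, and so the stronger inhibition of growth of that pair.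

The next structure is compound 4 (`COc1cc2c(/C=C3/C(=O)N(C)c4ccc(O)cc43)c[nH]c2cc1C`), which carries hydroxy in place of hydrogen on an aromatic carbon. Among the compounds with values here, no measured pair differs in one place only, so the data give no direct guide to this change. Within the data shown here, the only guide is the spread of the three numbers, which reaches no further than compound 1 at 15900 nM. In this assay a small move towards stronger inhibition is expected, but none beyond the scatter. The estimated change is a 1.5-fold lower number from compound 3 to compound 4 (0.18 log units; within the scatter). For compound 4 the expected value is 40000 nM, with an estimated range of 15000 nM to 90000 nM.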

Compound 4, concentration for total growth inhibition: 28200 nM
For compound 4 the middle estimate is 1.4-fold (0.15 log units) above the measured one; the measured number falls inside the stated range.
By their numbers in this assay, from the lowest: compounds 1, 4, 2 and 3 (each within the scatter of the next, the first and the last beyond it).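

In this assay the series gains its first step that differs in one place only: hydroxy in place of hydrogen on an aromatic carbon (a 2.1-fold lower number from compound 3 to compound 4 (0.33 log units; beyond the scatter)), a modest move towards stronger inhibition of growth. This position, on a six-membered aromatic ring of carbon only, meta to a fused ring and para to a fused ring, therefore accepts hydroxy with a gain rather than a loss on this read-out. Nothing at hand bears on the reason for this step.

As far as these compounds go, whether the gain is specific to hydroxy stays open, as an amine or a carboxylic acid at the same position would be needed to show how far it extends. Also open, from the compounds shown here alone, is whether the same change carries over to the core of compound 1 or that of compound 2.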